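The compounds below may be only part of what the source reports. "The series", "measured", "known", "first", "only" and "open" are said of these compounds alone.

Measured compounds:
- Compound 1, `CCCCCCCCC[C@]1(CO)NC[C@@H](O)[C@@H]1O`: 130000 nM
- Compound 2, `C[C@@]1(CO)NC[C@H](O)[C@H]1O`: 5600 nM
- Compound 3, `C[C@]1(CO)NC[C@@H](O)[C@@H]1O`: 16000 nM

In an assay on isolated protein for inhibition of lysosomal alpha-glucosidase (Homo sapiens) (on this read-out higher numbers stand for weaker inhibition and lower numbers for stronger inhibition), compound 3 gives 16000 nM, the second highest of the three numbers. Its nearest neighbour is compound 2, the mirror image, and the step from compound 2 to compound 3 is a 2.9-fold higher number from compound 2 to compound 3 (0.46 log units; beyond the scatter); the only difference between these two is the fact that compounds 2 and 3 differ only in the configuration as drawn. Compound 1 carries a long nonyl chain on the same core with the same configuration as the methyl-bearing compound of the same handedness, and in this assay compound 1 gives 130000 nM, the highest number of the three.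

Compound 4, `CCCC[C@]1(CO)NC[C@@H](O)[C@@H]1O`, is compound 3 with a change on the chain: propyl in place of hydrogen on a saturated chain carbon bound to a saturated ring carbon. For the measured compounds named here, no measured step covers exactly this kind of change, since the one step available concerns configuration only. What the values show is that compound 1 with a nonyl chain stands well above compound 3 with a methyl group, and compound 4 with its butyl chain lies between those two in chain length. Compound 4 is therefore expected to sit between compound 3 and compound 1, with a step of a 2.5-fold higher number from compound 3 to compound 4 (0.40 log units; beyond the scatter) towards a higher number. The estimate for compound 4 in this assay is 40000 nM, with a range from 12000 nM to 130000 nM.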

Compound 4, half-maximal inhibitory concentration: 79000 nM
The estimate for compound 4 lay 2.0-fold (0.30 log units) below the measured number; measured number inside the range.
By their numbers in this assay, from the lowest: compound 2; then compound 3; then compounds 4 and 1 (each within the scatter of the next).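

Putting propyl in place of hydrogen on a saturated chain carbon bound to a saturated ring carbon weakens inhibition in this assay, giving a 4.9-fold higher number from compound 3 to compound 4 (0.69 log units; beyond the scatter), so this position does respond to a modest extension of the chain. Extending the chain further brings no change that can be resolved, with a 1.6-fold lower number from compound 1 to compound 4 (0.22 log units; within the scatter), so the butyl chain of compound 4 and the nonyl chain of compound 1 cannot be told apart here, and the rise seen on going from methyl to butyl is not shown to continue with further length. The one available fact concerns configuration alone and offers no explanation for this effect of the chain.

Going by these compounds, it remains open whether a shorter ethyl chain already gives part of this rise, and whether a butyl chain has the same effect on the mirror-image form represented by compound 2. Also open, on these data alone, is how this position would respond to a chain ending in a hydroxyl group, an amine or a carboxylic acid, or to one carrying a phenyl ring.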